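Replacing the styryl arm of compound 3 with a biaryl

This account rests on a few compounds, and the source may have more. Where it says the series, first, only, none or still open, it means among the compounds named here.

Compound 3 `COC(=O)/C=C/c1cccc(N(Cc2ccc(/C=C/c3cccc(Cl)c3)cc2)C(=O)C2CCCCC2)c1` gives 165 nM in an assay on isolated protein with Bile acid receptor (Homo sapiens) as the target; on this read-out higher numbers stand for an effect only at larger amounts of compound and lower numbers for an effect already at smaller amounts; this is the lowest of the three numbers measured, with compound 2 `COC(=O)/C=C/c1cccc(N(Cc2ccc(-c3cccc(C(C)=O)c3)cc2)C(=O)C2CCCCC2)c1` at 227 nM nearest and compound 1 `COC(=O)/C=C/c1cccc(N(Cc2ccc(/C=C/c3ccccn3)cc2)C(=O)C2CCCCC2)c1` at 309 nM furthest, both gaps within the scatter. Compound 4 `COC(=O)/C=C/c1cccc(N(Cc2ccc(-c3cc(Cl)ccc3OC)cc2)C(=O)C2CCCCC2)c1` carries 5-chloro-2-methoxyphenyl in place of 2-(3-chlorophenyl)ethenyl on an aromatic carbon. The bearing steps are a 1.4-fold lower number from compound 2 to compound 3 (0.14 log units; within the scatter), where a biaryl gives way to the styryl arm, and a 1.9-fold lower number from compound 1 to compound 3 (0.27 log units; within the scatter), where only the distal ring changes; both are within the scatter. Within the data shown here, compounds 1 and 2 share neither the arm nor the distal group of compound 4 and no step between them is computed for it, but their two values sit close to each other. The move back from styryl to a directly attached phenyl is therefore expected to give no step beyond the scatter in this assay, at most a small shift towards a higher number, as a 1.5-fold higher number from compound 3 to compound 4 (0.18 log units; within the scatter). Compound 4 is thus estimated at 250 nM, within the range 80 nM to 800 nM.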

Compound 4, half-maximal effective concentration: 233 nM
Beside the measured number, compound 4's estimate is 1.1-fold (0.03 log units) above it; the measured number falls inside the stated range.
By their numbers in this assay, from the lowest: compounds 3, 2, 4 and 1 (each within the scatter of the next).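

In this assay, the aromatic carbon para to a large group takes 5-chloro-2-methoxyphenyl, which has no double bond outside aromatic rings and carries one hydrogen-bond acceptor, in place of 2-(3-chlorophenyl)ethenyl with a step inside the scatter (a 1.4-fold higher number from compound 3 to compound 4 (0.15 log units; within the scatter)). The same group also stays within the scatter of the other two arms (a 1.0-fold higher number from compound 2 to compound 4 (0.01 log units; within the scatter); a 1.3-fold lower number from compound 1 to compound 4 (0.12 log units; within the scatter)), so the four arms shown, two ethenyl-linked and two directly attached, cannot be told apart at this position. No supporting data explain this flat picture.

As far as these compounds go, whether an amine or a carboxylic acid on the distal ring, or a longer chain in place of the ethenyl link, moves the number beyond the scatter remains open. The compounds shown also do not separate the methoxy from the chloro within 5-chloro-2-methoxyphenyl.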